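Compound 4 and the swap from bromo to ethoxy

A few compounds are considered here, and "the series" means these few. Any claim that something is new, unique, unknown or untested is made for them only; others in the source may bear on it.

Measured in a functional assay on MCF7 cells (Homo sapiens) for inhibition, read by sulforhodamine B assay; on this read-out higher numbers stand for weaker inhibition and lower numbers for stronger inhibition:
Compound 1 `O=C1C(Nc2ccc(Br)cc2)=CC(=O)c2c1nc1n2[C@H]2OC[C@@H](O)[C@H]2OC1` gives 4330 nM
Compound 2 `CCc1ccc(NC2=CC(=O)c3nc4n(c3C2=O)[C@H]2OC[C@@H](O)[C@H]2OC4)cc1` gives 960 nM
Compound 3 `CCOc1ccccc1NC1=CC(=O)c2nc3n(c2C1=O)[C@H]1OC[C@@H](O)[C@H]1OC3` gives > 4000 nM (a limit)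

Compound 1, at 4330 nM, holds the higher of the two exact numbers, and compound 2 gives 960 nM, which stands for stronger inhibition. The value of compound 3 is a limit and not a number.

Compound 4 `CCOc1ccc(NC2=CC(=O)c3c(nc4n3[C@H]3OC[C@@H](O)[C@H]3OC4)C2=O)cc1` has not yet been measured. It departs from compound 1 by ethoxy in place of bromo on an aromatic carbon, which is ethoxy in place of bromo on an aromatic carbon, para to a large group.

Among the compounds with values here, one measured step bears on this, an at least 4.1-fold higher number from compound 2 to compound 3 (0.61 log units; beyond the scatter), and it is beyond the scatter. It swaps 4-ethylphenyl for 2-ethoxyphenyl, so it warns that an ethoxy group does not guarantee a low number, yet it does not test the 4-ethoxyphenyl group itself. Its size is only a bound, given the limit of > 4000 nM in this assay, at which 1 of the 3 values shown sits, in this assay. Compound 2, at 960 nM with its 4-ethylphenyl group, offers the closer comparison and suggests a modest move towards stronger inhibition.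

The expected change is a 2.4-fold lower number from compound 1 to compound 4 (0.38 log units; beyond the scatter), a step towards a lower number that may prove small. Compound 4 is therefore estimated at 1800 nM, with an expected range from 600 nM to 5000 nM.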

Compound 4, half-maximal inhibitory concentration: > 4000 nM
Compound 4 ended at the assay's limit; the forecaster's own chance of this, stated with the estimate: 15%; at least 2.2-fold (0.34 log units) between middle value and limit.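

In this assay, within the data shown here, compound 4 gives > 4000 nM, which is a limit and not a number, so no step from compound 1 to compound 4 can be read. The compounds shown leave open how 4-ethoxyphenyl compares with 4-bromophenyl, and exact numbers are missing at the top of the range: the limit of > 4000 nM in this assay, at which 2 of the 4 values shown sit.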